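A Second Chlorine on the Shared Core

The source may hold more compounds than are shown below. What is called first, only, known or untested is meant among the compounds shown, and "the series" means these compounds.

Measured compounds:
compound 1 `ClCc1ccccc1Cn1cnc2c(Cl)ncnc21` — 6160 nM
compound 2 `ClCc1cccc(Cn2cnc3ncnc(Cl)c32)c1` — 3980 nM

Both numbers come from a functional assay on U-251 cells (Homo sapiens) for cytotoxicity, read by sulforhodamine B assay, with a stated time of 48 h; a lower number here means a stronger inhibitor of growth, a higher number a weaker inhibitor of growth. Compound 2 carries the lower of the two numbers, but the gap to compound 1 lies within the usual scatter, so neither compound can be called the stronger one. Compound 3 `ClCc1cccc(Cn2cnc3nc(Cl)nc(Cl)c32)c1` has not yet been measured. It differs from compound 2 in a single respect: chloro in place of hydrogen on an aromatic carbon. Among the measured compounds shown here, no pair of measured compounds shows what this change does in this assay, so there is no measured step to lean on. The expected step is a 1.3-fold lower number from compound 2 to compound 3 (0.12 log units; within the scatter), that is, no shift beyond the scatter in either direction. Compound 3 is therefore expected to give about 3000 nM in this assay, with a likely range from 1000 nM to 9000 nM.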

Compound 3, concentration for total growth inhibition: 2690 nM
Compound 3: middle estimate off by 1.1-fold (0.05 log units), on the high side, within the range that was stated.
By their numbers in this assay, from the lowest: compounds 3, 2 and 1 (each within the scatter of the next, the first and the last beyond it).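

In this assay, among the compounds shown here, chloro in place of hydrogen on the aromatic carbon between two ring nitrogen atoms gives a 1.5-fold lower number from compound 2 to compound 3 (0.17 log units; within the scatter) as the first measured step for this change. The added chlorine atom therefore brings no shift that can be told apart from ordinary repeat variation, and the number for compound 3 stays in the same range as that for compound 2. No measurement shown here explains this outcome or links it to any property of the group.

For the compounds shown here, only one group has been seen at this carbon, so it remains open whether an amine or a methoxy group there would give a number beyond the scatter. Also open, as far as these compounds go, is whether the same change on compound 1 would give a similar step.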